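Trading a Cyclopropyloxycarbonyl Group for a Methylpyrimidinyl Group

A few compounds are considered here, and "the series" means these few. Any claim that something is new, unique, unknown or untested is made for them only; others in the source may bear on it.

Of the compounds shown here, three have been tested in an assay on HeLa cells for inhibition of Indoleamine 2,3-dioxygenase 1 (Homo sapiens); a lower number here means a stronger inhibitor, a higher number a weaker inhibitor. Compound 1 `O=C(OC1CC1)N1CCc2cc(C3(C(=O)Nc4ccc(F)cc4)CCC3)ccc21` gives 1.4 nM, the lowest of the three numbers. Compound 3 `O=C(C1CC1)N1CCc2nc(C3(C(=O)Nc4ccc(F)cc4)CCC3)ccc21` gives 8 nM, and compound 2 `O=C(NCc1ccc2c(c1)CCN2C(=O)c1cccc(Cl)c1)c1ccc(Cl)cc1` gives 90 nM; both gaps from compound 1 lie beyond the usual scatter. Compound 4 `Cc1nccc(N2CCc3cc(C4(C(=O)Nc5ccc(F)cc5)CCC4)ccc32)n1` has not yet been measured. It differs from compound 1 in one place: 2-methylpyrimidin-4-yl in place of cyclopropyloxycarbonyl on a nitrogen on an aromatic ring in a ring. Going by the values given here, no measured pair shows this exact change, so nothing directly tells how large a step to expect. As the rest of compound 1 is kept intact, compound 4 is expected to stay potent, with a modest loss as the more likely direction. The estimated step is a 2.9-fold higher number from compound 1 to compound 4 (0.46 log units; beyond the scatter). Compound 4 is expected to give about 4 nM, within a range from 1 nM to 15 nM.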

Compound 4, half-maximal inhibitory concentration: 5.2 nM
For compound 4 the middle estimate is 1.3-fold (0.11 log units) below the measured one; measured number inside the range.
By their numbers in this assay, from the lowest: compound 1; then compounds 4 and 3 (each within the scatter of the next); then compound 2.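

Replacing cyclopropyloxycarbonyl with 2-methylpyrimidin-4-yl on this nitrogen gives a 3.7-fold higher number from compound 1 to compound 4 (0.57 log units; beyond the scatter) in this assay. The change is modest but lies beyond the scatter, so a carbonyl attached to this nitrogen is not needed for strong inhibition, although the exchange does carry a small cost. No measurement shown explains the size of this step.

The compounds shown leave open which part of the new ring matters. A plain phenyl ring, or a pyrimidine without the methyl group, at this nitrogen would help separate the contributions of the ring nitrogens and the methyl group.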